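Series notes: acyl change from compound 3 to compound 4

A few compounds are considered here, and "the series" means these few. Any claim that something is new, unique, unknown or untested is made for them only; others in the source may bear on it.

Three compounds carry numbers in an assay on RBL cells for inhibition of Polyunsaturated fatty acid 5-lipoxygenase (Rattus norvegicus); on this read-out lower numbers stand for stronger inhibition and higher numbers for weaker inhibition. Compound 1 `COc1cc(-c2cc3cc(C(C)N(O)C(C)=O)ccc3o2)cc(OC)c1OC` gives 310 nM. Compound 2 `COc1ccc2cc(-c3cc4cc(C(C)N(O)C(C)=O)ccc4o3)ccc2c1` gives 120 nM. Compound 3 `CC(c1ccc2oc(-c3ccccc3)cc2c1)N(O)C(=O)c1ccccc1` gives 4830 nM, the highest of the three numbers; its gap to compound 1 and its gap to compound 2 both lie beyond the usual scatter, so compound 3 is the weakest inhibitor among the three measured. Among the measured compounds shown here, compound 1 and compound 2 differ from compound 3 in more than one place, so no single-point step among measured compounds is available.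

Compound 4 `CC(c1ccc2oc(-c3ccccc3)cc2c1)N(O)C(=O)c1ccco1` has not yet been measured. It differs from compound 3 in one place: furan-2-yl in place of phenyl on a carbonyl carbon. For the measured compounds named here, no measured pair shows this change, and nothing among the measured compounds isolates the part of the structure attached to the carbonyl carbon. The step is therefore expected to be small, a 1.2-fold lower number from compound 3 to compound 4 (0.08 log units; within the scatter), with no direction expected beyond the scatter. Compound 4 is estimated at 4000 nM, within a range from 1200 nM to 13000 nM.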

Compound 4, half-maximal inhibitory concentration: 40 nM
Beside the measured number, compound 4's estimate is 100-fold (2.00 log units) above it, and the stated range ends above it.
By their numbers in this assay, from the lowest: compound 4; then compound 2; then compound 1; then compound 3.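

The group on this carbonyl carbon turns out to be a strong control point in this assay: furan-2-yl in place of phenyl gives a 120-fold lower number from compound 3 to compound 4 (2.08 log units; beyond the scatter), so a change at this one place can move the read-out far beyond the scatter. The change replaces a six-membered aromatic ring of carbon only with a five-membered aromatic ring with 1 hetero atom, and this single pair cannot tell which of these differences carries the step. Nothing available speaks to why the step is so large.

Still open, going by these compounds, is whether the ring oxygen itself matters, which a thiophen-2-yl or cyclopentyl group on this carbonyl carbon would help to settle. On these data alone, it is also open whether furan-2-yl gives a step of similar size on the cores of compound 1 and compound 2.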